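The source may hold more compounds than are shown below. What is called first, only, known or untested is meant among the compounds shown, and "the series" means these compounds.

Measured compounds in a functional assay on DLA cells (Mus musculus) for cytotoxicity, read by trypan blue exclusion, with a stated time of 48 h; a higher number here means a weaker inhibitor, a lower number a stronger inhibitor:

compound 1 `Cc1cc(C(=O)c2ccc(F)cc2)ccc1OCC(=O)Nc1nc(-c2ccccc2)cs1`: 32100 nM
compound 2 `COc1ccc(-c2csc(NC(=O)COc3ccc(C(=O)c4ccc(F)cc4)cc3C)n2)cc1`: 5000 nM
compound 3 `O=C(COc1ccc(C(=O)c2ccccc2)cc1Br)Nc1nc(-c2ccccc2)cs1`: 42000 nM

Compound 1 stands second highest of the three numbers. Its nearest neighbour is compound 3, whose number is within the scatter of that of compound 1, so no order between the two can be read. Going by the values given here, the furthest is compound 2: the step of a 6.4-fold lower number from compound 1 to compound 2 (0.81 log units; beyond the scatter) is beyond the scatter and is the only single-point change measured.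

Compound 4 `Cc1cc(C(=O)c2ccccc2C)ccc1OCC(=O)Nc1nc(-c2ccccc2)cs1` is the next compound to be measured. It differs from compound 1 as 2-methylphenyl in place of 4-fluorophenyl on a carbonyl carbon. Among the compounds with values here, none of the measured steps touches this place: the one measured step changes a substituent on an aromatic carbon of the other aryl group, not the group on the carbonyl carbon, and compounds 1 and 3 differ in two places at once. So nothing measured bears directly on the change from compound 1 to compound 4, and the default expectation in this assay is a step of no more than the scatter in either direction.

The estimate for compound 4 is therefore 30000 nM, with a range of 10000 nM to 90000 nM, which means an expected step of a 1.1-fold lower number from compound 1 to compound 4 (0.03 log units; within the scatter).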

Compound 4, half-maximal inhibitory concentration: 22200 nM
Compound 4: middle estimate off by 1.4-fold (0.13 log units), on the high side; the range from low to high includes it.
By their numbers in this assay, from the lowest: compound 2; then compounds 4, 1 and 3 (each within the scatter of the next).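

In this assay, going by these compounds alone, the first measured change to the group on the carbonyl carbon, 2-methylphenyl in place of 4-fluorophenyl, gives a 1.4-fold lower number from compound 1 to compound 4 (0.16 log units; within the scatter), so no order can be read between the two compounds and this exchange on the carbonyl carbon shows no effect beyond the scatter. Within the data shown here, the exchange alters both the substituent and the place it is printed on the ring, so a single comparison cannot separate the two, and a 6.4-fold lower number from compound 1 to compound 2 (0.81 log units; beyond the scatter) remains the only single-place step beyond the scatter, with methoxy in place of hydrogen on an aromatic carbon. No measurement at hand gives a reason for either result.

Whether the group on the carbonyl carbon matters at all in this assay remains open, since only aryl groups are shown there and a morpholine, a carboxylic acid or a longer alkyl chain in place of the aryl group could read quite differently. Also open, as far as these compounds go, is whether the methoxy step seen with 4-fluorophenyl on the carbonyl carbon would carry over to the compound bearing 2-methylphenyl there.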